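Permeability of a Shared Core with a Naphthyl Substituent

The compounds below may be only part of what the source reports. "The series", "measured", "known", "first", "only" and "open" are said of these compounds alone.

Measured compounds:
compound 1 `COc1ccc(F)cc1CNCCCNc1ccnc2cc(Cc3ccc(F)cc3Cl)ccc12` gives 23 10^-6 cm/s
compound 2 `COc1ccc(F)cc1CNCCCNc1ccnc2cc(-c3ccc(F)cc3)ccc12` gives 237 10^-6 cm/s
compound 3 `COc1ccc(F)cc1CNCCCNc1ccnc2cc(CCC(C)C)ccc12` gives 23 10^-6 cm/s

In an ADME assay for permeability, using PAMPA, with a stated time of 30 min, at pH 7.4 (a lower number here means that the compound crosses the layer more slowly, a higher number that the compound crosses the layer faster), compound 3 stands level with compound 1 and together they are the lowest of the three, while compound 2 sits well apart: a 10-fold lower number from compound 2 to compound 3 (1.01 log units; beyond the scatter). Compound 4 `COc1ccc(F)cc1CNCCCNc1ccnc2cc(-c3cccc4ccccc34)ccc12` has not been measured; it differs from compound 3 by naphthalen-1-yl in place of isopentyl on an aromatic carbon. Among the measured compounds shown here, the step that bears on this is the one between compound 2 and compound 3, where an aromatic group bound directly to the aromatic carbon went with a much higher number; its reverse is the closest guide. An upward step is therefore expected, roughly a 6.5-fold higher number from compound 3 to compound 4 (0.81 log units; beyond the scatter). Compound 4 is estimated to give 150 10^-6 cm/s, within 40 10^-6 cm/s to 400 10^-6 cm/s.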

Compound 4, apparent permeability: 237 10^-6 cm/s
Estimate against measurement, compound 4: 1.6-fold (0.20 log units) below, within the range that was stated.
By their numbers in this assay, from the lowest: compounds 1 and 3 (each within the scatter of the next); then compounds 2 and 4 (each within the scatter of the next).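

In this assay the higher level at this position is not tied to 4-fluorophenyl, since naphthalen-1-yl reaches it too, with a 10-fold higher number from compound 3 to compound 4 (1.01 log units; beyond the scatter) and a 10-fold higher number from compound 1 to compound 4 (1.01 log units; beyond the scatter). Exchanging 4-fluorophenyl for naphthalen-1-yl, with its two six-membered aromatic rings of carbon only, gives no change at the digits printed from compound 2 to compound 4 (within the scatter). The data at hand offer no explanation for this pattern. The compounds shown leave open whether an aromatic ring containing nitrogen, such as pyridyl, would stand at the same level on this aromatic carbon. They also leave open where a cyclohexyl ring bound directly to that carbon would fall.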